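Chlorine on the Pendant Phenyl: Cytotoxicity Tolerance Expected

The compounds below may be only part of what the source reports. "The series", "measured", "known", "first", "only" and "open" are said of these compounds alone.

Measured compounds:
compound 1, `O[C@@H]1Cc2cc(OC(F)(F)F)ccc2N[C@H](c2ccccc2)C1`: 124000 nM
compound 2, `O[C@@H]1Cc2cc(Cl)ccc2N[C@H](c2ccccc2)C1`: 191000 nM
compound 3, `O[C@@H]1Cc2cc(F)ccc2N[C@H](c2ccccc2)C1`: limit, > 300000 nM

In an ADME assay on Vero cells (Chlorocebus sabaeus) for cytotoxicity, read by MTT assay, with a stated time of 72 h (a lower number here means that less compound is tolerated, a higher number that more compound is tolerated), compound 2 gives 191000 nM, the highest of the two plain numbers; compound 1 sits near it, the step of a 1.5-fold higher number from compound 1 to compound 2 (0.19 log units; within the scatter) being within the scatter. Compound 3 reaches only a limit of this assay the limit of > 300000 nM in this assay, at which 1 of the 3 values shown sits, and gives no number. Compound 4, `O[C@@H]1Cc2cc(Cl)ccc2N[C@H](c2ccccc2Cl)C1`, differs from compound 2 by chloro in place of hydrogen on an aromatic carbon. Going by the values given here, none of the measured steps touches this ring: a 1.5-fold higher number from compound 1 to compound 2 (0.19 log units; within the scatter), an at least 2.4-fold higher number from compound 1 to compound 3 (0.38 log units; beyond the scatter) and an at least 1.5-fold higher number from compound 2 to compound 3 (0.19 log units; that floor lies within the scatter) all swap groups on the other aromatic carbon, and the largest of them is only modest. Compound 4 is therefore expected to show no step beyond the scatter, a 1.2-fold lower number from compound 2 to compound 4 (0.08 log units; within the scatter), with an estimate of 160000 nM ranging from 70000 nM to 300000 nM.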

Compound 4, half-maximal cytotoxic concentration: 106000 nM
For compound 4 the middle estimate is 1.5-fold (0.18 log units) above the measured one; the range from low to high includes it.
By their numbers in this assay, from the lowest: compounds 4, 1 and 2 (each within the scatter of the next). At a limit, above all of these: compound 3.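

In this assay, chloro in place of hydrogen on an aromatic carbon, ortho to a large group, gives a 1.8-fold lower number from compound 2 to compound 4 (0.26 log units; within the scatter) as the first change shown on this ring. Compound 2 and compound 4 thus cannot be told apart in this read-out, so this position takes a single chlorine without a step beyond the scatter. Nothing shown bears on the cause of this small step. As far as these compounds go, whether an amine or a carboxylic acid at this position would give a step beyond the scatter remains open.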